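A few compounds are considered here, and "the series" means these few. Any claim that something is new, unique, unknown or untested is made for them only; others in the source may bear on it.

Compound 1, `COc1ccc(COc2ccc(OCCOCCNC3CCCC3)cc2)cc1`, gives 15700 nM in a functional assay on SK-OV-3 cells (Homo sapiens) for inhibition, read by CCK-8 assay, with a stated time of 70 h; on this read-out lower numbers stand for stronger inhibition and higher numbers for weaker inhibition.
Compound 2, `OCCOCCOCCOc1ccc(OCc2ccccc2)cc1`, gives 59400 nM in this assay.
Compound 3, `c1ccc(COc2ccc(OCCOCCNC3CCCCC3)cc2)cc1`, gives 7370 nM in this assay.

Among these three numbers compound 1 stands second highest. Its nearest neighbour is compound 3, whose number is lower by a margin beyond the scatter, and its furthest is compound 2, whose number is higher, again beyond the scatter. Going by the values given here, the only measured step between compounds that differ in one place is an 8.1-fold lower number from compound 2 to compound 3 (0.91 log units; beyond the scatter); it concerns the group at the end of the saturated chain and leaves the benzyl ring untouched.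

Compound 4, `Cc1ccc(COc2ccc(OCCOCCNC3CCCC3)cc2)cc1`, differs from compound 1 at that benzyl ring: methyl in place of methoxy on an aromatic carbon. Among the compounds with values here, none of the measured compounds probes a substituent on this ring, so no measured step bears on the change, and the one step that is known acts elsewhere in the molecule. With nothing to point either way, the expected step of a 1.2-fold lower number from compound 1 to compound 4 (0.08 log units; within the scatter) is one that stays within the usual scatter, in no particular direction. Compound 4 is therefore estimated at 13000 nM in this assay, with a range from 4500 nM to 40000 nM.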

Compound 4, half-maximal inhibitory concentration: 17200 nM
The estimate for compound 4 lay 1.3-fold (0.12 log units) below the measured number, within the range that was stated.
By their numbers in this assay, from the lowest: compound 3; then compounds 1 and 4 (each within the scatter of the next); then compound 2.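

At this place on the benzyl ring, para to a large group, the exchange of 4-methoxybenzyl for 4-methylbenzyl gives a 1.1-fold higher number from compound 1 to compound 4 (0.04 log units; within the scatter) in this assay, so compound 1 and compound 4 cannot be told apart on this read-out. Going by these compounds alone, this is the first reading of any substituent on that ring, and it shows that losing the oxygen of the methoxy group, with the one hydrogen-bond acceptor counted for it, leaves the number within the scatter, whereas the only earlier step, an 8.1-fold lower number from compound 2 to compound 3 (0.91 log units; beyond the scatter), lay at the far end of the saturated chain and went beyond the scatter. No measured information accompanies these numbers that could say why this exchange leaves so little mark.

The two groups compared here are the only ones shown at this place, so the compounds leave open whether a chlorine, a nitrile, a carboxylic acid or an amine there, or a bare hydrogen, would stay within the scatter of compound 1 or move beyond it. They also leave open whether a methoxy or methyl group at another carbon of the same ring would read the same way.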